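The compounds below may be only part of what the source reports. "The series", "measured", "known", "first", "only" and "open" are said of these compounds alone.

Compound 2 `COc1cc2c(Oc3ccc(NC(=O)c4cc(-c5cccc(Cl)c5)nc5ccc(F)cc45)cc3F)ccnc2cc1OCCCN1CCC(C)CC1` gives 60 nM in a functional assay on NCI-H460 cells (Homo sapiens) for cytotoxicity, read by MTT assay, with a stated time of 72 h (on this read-out lower numbers stand for stronger inhibition and higher numbers for weaker inhibition), the lowest of the three numbers at hand. Compound 1 `COc1cc2c(Oc3ccc(NC(=O)c4cc(-c5cccc(Cl)c5)nc5ccccc45)cc3F)ccnc2cc1OCCCN1CCC(C)CC1` sits closest to it with 65 nM, and a 1.1-fold lower number from compound 1 to compound 2 (0.03 log units; within the scatter) shows the two within the scatter, so no order between them can be read. Compound 3 `COc1cccc(-c2cc(C(=O)Nc3ccc(Oc4ccnc5cc(OCCCN6CCC(C)CC6)c(OC)cc45)c(F)c3)c3cc(F)ccc3n2)c1` is the furthest away with 840 nM, and a 14-fold higher number from compound 2 to compound 3 (1.15 log units; beyond the scatter) is a large step beyond the scatter.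

Compound 4 `COc1cc2c(Oc3ccc(NC(=O)c4cc(-c5cccc(Cl)c5)nc5ccc(F)cc45)cc3F)ccnc2cc1OCCCN1CCCC1` is the untested compound. Compared with compound 2 it carries pyrrolidin-1-yl in place of 4-methylpiperidin-1-yl on a saturated chain carbon, three bonds along the chain from an oxygen on an aromatic ring.

Neither measured step touches this part of the molecule: the step from compound 1 to compound 2 concerns a fluoro on an aromatic carbon, and the step from compound 2 to compound 3 concerns a methoxy in place of a chloro on an aromatic carbon, far from the chain end. There is thus no measured evidence on the chain-end amine. In the absence of such evidence, the expectation for compound 4 is a step of about a 1.3-fold higher number from compound 2 to compound 4 (0.12 log units; within the scatter), that is, no change beyond the scatter. The estimated value for compound 4 is 80 nM, with a range from 30 nM to 250 nM.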

Compound 4, half-maximal inhibitory concentration: 72 nM
Beside the measured number, compound 4's estimate is 1.1-fold (0.05 log units) above it; the range from low to high includes it.
By their numbers in this assay, from the lowest: compounds 2, 1 and 4 (each within the scatter of the next); then compound 3.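

Among these compounds, the exchange of 4-methylpiperidin-1-yl for pyrrolidin-1-yl gives the first measured step at the chain end: in this assay there is a 1.2-fold higher number from compound 2 to compound 4 (0.08 log units; within the scatter) on going to the five-membered ring. On this read-out, therefore, a 3-(pyrrolidin-1-yl)propyl chain cannot be told apart from a 3-(4-methylpiperidin-1-yl)propyl chain, and for this one pair the ring size and the ring methyl group together leave no visible mark, in contrast to the large step seen for methoxy in place of chloro on an aromatic carbon. Nothing on hand gives a reason for this outcome.

This single pair leaves open how far the result extends: a morpholin-4-yl or a dimethylamino group at the chain end, an end carrying a carboxylic acid, or a shorter or longer chain than the propyl linker could each behave differently in this assay and remain to be seen. On these data alone, it is also open whether pyrrolidin-1-yl would be matched by 4-methylpiperidin-1-yl in the same way on the methoxy-bearing series of compound 3 or on the unfluorinated series of compound 1.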